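Aryl amide change from compound 3 to compound 4

The compounds below may be only part of what the source reports. "The series", "measured", "known", "first", "only" and "open" are said of these compounds alone.

- compound 1 `CN(C)C(=O)c1cc2cnc(Nc3ccc(NC(=O)C4(C(=O)Nc5cccc(F)c5)CC4)cc3)nc2n1C1CCCC1`: 87%
- compound 2 `CN(C)C(=O)c1cc2cnc(Nc3ccc(NC(=O)C4(C(=O)Nc5cccc(O)c5)CC4)cc3)nc2n1C1CCCC1`: 78.5%
- compound 3 `CN(C)C(=O)c1cc2cnc(Nc3ccc(NC(=O)C4(C(=O)Nc5ccccc5F)CC4)cc3)nc2n1C1CCCC1`: 89.6%

All three values come from a functional assay on NCI-H1299 cells (Homo sapiens) for inhibition, read by CCK-8 assay, with a stated time of 72 h, tested at 10 uM; a higher number here means more inhibition of growth at the concentration tested, a lower number less inhibition of growth. Compound 3 carries the largest number of the three, but the lead over one neighbour is not meaningful: the data show a number 2.6 percentage points higher from compound 1 to compound 3 (within the scatter). The gap on the other side is real but small: a number 11.1 percentage points higher from compound 2 to compound 3 (beyond the scatter).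

Compound 4 `CN(C)C(=O)c1cc2cnc(Nc3ccc(NC(=O)C4(C(=O)Nc5cccc(Cl)c5)CC4)cc3)nc2n1C1CCCC1` keeps the shared core and changes only the aryl group: 3-chlorophenyl in place of 2-fluorophenyl on an amide-type nitrogen. In words, 3-chlorophenyl stands in place of 2-fluorophenyl on an amide-type nitrogen.

For the measured compounds named here, no measured compound carries 3-chlorophenyl, so the evidence is indirect. The closest comparison is compound 1, with 3-fluorophenyl, at 87%. Going between the two fluorophenyl groups gave a number 2.6 percentage points higher from compound 1 to compound 3 (within the scatter), so that part of the change is not expected to matter much. Going by the values given here, the only other substituent change gave a number 8.5 percentage points lower from compound 1 to compound 2 (within the scatter), which also stays small.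

On these grounds, the expected step in this assay is a number 2.6 percentage points lower from compound 3 to compound 4 (within the scatter), with no shift beyond the scatter anticipated. For compound 4 the estimated value is 87%, with an expected range from 77% to 95%.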

Compound 4, percent growth inhibition at one concentration: 84.1%
The estimate for compound 4 lay 2.9 percentage points above the measured number, and the stated range covers the measured number.
By their numbers in this assay, from the lowest: compounds 2, 4, 1 and 3 (each within the scatter of the next, the first and the last beyond it).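

Working notes on the aryl amide: in this assay, a chloro group is tolerated on this aryl ring as well as a fluoro group, with chloro in place of fluoro giving a number 2.9 percentage points lower from compound 1 to compound 4 (within the scatter). Changing both the halogen and the printed position of the substituent also leaves the read-out within the scatter, with 3-chlorophenyl in place of 2-fluorophenyl on the amide-type nitrogen giving a number 5.5 percentage points lower from compound 3 to compound 4 (within the scatter). The one gap beyond the scatter so far, a number 11.1 percentage points higher from compound 2 to compound 3 (beyond the scatter), does not recur with the new halogen, since chloro in place of hydroxy gives a number 5.6 percentage points higher from compound 2 to compound 4 (within the scatter), so the 3-hydroxyphenyl group is set apart from 2-fluorophenyl alone and not from the halogenated aryl groups as a set.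

The compounds shown leave open whether this tolerance extends to a basic amine such as dimethylaminomethyl, a carboxylic acid or a longer alkoxy chain on the aryl ring, and readings at one concentration cannot rank the halogenated compounds by potency. Nothing available explains why these aryl groups read as they do.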